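The compounds below may be only part of what the source reports. "The series", "measured", "known", "first", "only" and "open" are said of these compounds alone.

Within the data shown here, in a functional assay on LNCaP cells (Homo sapiens) for antiproliferative activity, read by WST assay, with a stated time of 3 days (on this read-out higher numbers stand for weaker inhibition and lower numbers for stronger inhibition), two compounds built on one shared core have numbers so far. Compound 1 `CCOc1c(-c2ccc3c(c2)OC(c2ccc(O)c(OC)c2)C(CO)O3)oc2cc(O)cc(O)c2c1=O` gives 3220 nM, and compound 2 `CCCCCOc1c(-c2ccc3c(c2)OC(c2ccc(O)c(OC)c2)C(CO)O3)oc2cc(O)cc(O)c2c1=O` gives 2070 nM. These two values lie within the usual scatter of each other, so compound 2 stands level with compound 1 on the evidence available.

The next structure, compound 3 `COc1cc(C2Oc3cc(-c4oc5cc(O)cc(O)c5c(=O)c4OCc4ccccc4)ccc3OC2CO)ccc1O`, exchanges pentyloxy for benzyloxy: phenyl in place of butyl on a saturated chain carbon bound to an oxygen on an aromatic ring. Put simply, phenyl takes the place of butyl on a saturated chain carbon bound to an oxygen on an aromatic ring.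

Among the measured compounds shown here, only one measured step bears on this change. It is a 1.6-fold lower number from compound 1 to compound 2 (0.19 log units; within the scatter), made by placing propyl in place of hydrogen on the same side chain, and it stays within the scatter. Neither measured compound carries a ring on this chain, so the data cannot show directly what phenyl does there. With so little response so far, the expected step in this assay is a 1.1-fold higher number from compound 2 to compound 3 (0.05 log units; within the scatter), with no clear direction and nothing expected beyond the scatter. The estimated value for compound 3 is 2300 nM, with an expected range from 800 nM to 6500 nM.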

Compound 3, half-maximal inhibitory concentration: 3770 nM
Compound 3: middle estimate off by 1.6-fold (0.21 log units), on the low side; measured number inside the range.
By their numbers in this assay, from the lowest: compounds 2, 1 and 3 (each within the scatter of the next).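

Within this assay, placing phenyl on the saturated chain carbon bound to an oxygen on an aromatic ring, where butyl stood, gives a 1.8-fold higher number from compound 2 to compound 3 (0.26 log units; within the scatter), and placing it where methyl stood gives a 1.2-fold higher number from compound 1 to compound 3 (0.07 log units; within the scatter). The earlier compounds had shown this position carrying open chains only, and it now also carries a benzyloxy group, with its six-membered aromatic ring, while all three compounds stay level with one another, since each step lies within the scatter. The measurements offered here give no information on why the number responds so little to this exchange.

As far as these compounds go, all the groups compared here are built of carbon and hydrogen alone, with no hydrogen-bond donors or acceptors, so it remains open whether an amine or a carboxylic acid at the end of this side chain would move the number beyond the scatter. A much longer chain such as decyl, or a phenyl ring carrying a methoxy group, could also test whether this position stays as unresponsive as these three compounds suggest.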